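This account rests on a few compounds, and the source may have more. Where it says the series, first, only, none or still open, it means among the compounds named here.

Compound 3 `O=C1O[C@@H](CNC(=O)C(F)(F)F)CN1c1ccc(-n2cc(-c3ccccn3)cn2)c(F)c1` gives the highest number of the three in a physicochemical assay for solubility, read by HPLC, with a stated time of 24 h (on this read-out higher numbers stand for higher solubility and lower numbers for lower solubility), at 114000 nM. Compound 2 `O=C(NC[C@H]1CN(c2ccc(-n3cc(-c4ccccn4)cn3)c(F)c2)C(=O)O1)C(F)F` gives 29900 nM and compound 1 `O=C1CSC(=O)N1C[C@H]1CN(c2ccc(-n3cc(-c4ccccn4)cn3)c(F)c2)C(=O)O1` gives 26900 nM; the steps of a 3.8-fold higher number from compound 2 to compound 3 (0.58 log units; beyond the scatter) and a 4.2-fold higher number from compound 1 to compound 3 (0.63 log units; beyond the scatter) both lie beyond the scatter, while the step of a 1.1-fold higher number from compound 1 to compound 2 (0.05 log units; within the scatter) stays within it. Compound 4 `CNC(=O)[C@H]1CN(c2ccc(-n3cc(-c4ccccn4)cn3)c(F)c2)C(=O)O1` differs from compound 3 by methylcarbamoyl in place of (((trifluoromethyl)carbonyl)amino)methyl on a saturated ring carbon. Going by the values given here, none of the measured steps exchanges the whole side chain for a shorter amide, so they bear on it only indirectly: the two steps that moved beyond the scatter both rose on arriving at the trifluoromethyl carbonyl, and compound 4 gives that group up. A modest downward step is therefore expected, a 2.9-fold lower number from compound 3 to compound 4 (0.45 log units; beyond the scatter). Compound 4 is estimated at 40000 nM in this assay, within a range from 15000 nM to 110000 nM.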

Compound 4, solubility: 26200 nM
The estimate for compound 4 lay 1.5-fold (0.18 log units) above the measured number; low and high end bracket the measured number.
By their numbers in this assay, from the lowest: compounds 4, 1 and 2 (each within the scatter of the next); then compound 3.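

At this saturated ring carbon, the shorter methylcarbamoyl chain sits level with two larger side chains in this assay, showing a 1.1-fold lower number from compound 2 to compound 4 (0.06 log units; within the scatter) and a 1.0-fold lower number from compound 1 to compound 4 (0.01 log units; within the scatter) here. Only the (((trifluoromethyl)carbonyl)amino)methyl chain of compound 3 stands apart, with a 4.4-fold lower number from compound 3 to compound 4 (0.64 log units; beyond the scatter) on this change, so among these four compounds the exception is that one chain and not chain size. Nothing available explains this. On these data alone, whether an amine, a carboxylic acid or a longer chain at this carbon would keep this level remains open.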